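Amino in place of chloro: carrying one step to compound 4

The compounds below may be only part of what the source reports. "The series", "measured", "known", "first", "only" and "open" are said of these compounds alone.

Measured so far in a functional assay on HT-29 cells (Homo sapiens) for cytotoxicity, read by sulforhodamine B assay, with a stated time of 48 h; on this read-out lower numbers stand for stronger inhibition of growth and higher numbers for weaker inhibition of growth:
Compound 1, `ClCc1ccccc1Cn1cnc2c(Cl)nc(Cl)nc21`, gives > 100000 nM, which is a limit of the assay.
Compound 2, `ClCc1cccc(Cn2cnc3c(Cl)nc(Cl)nc32)c1`, gives > 100000 nM, also a limit of the assay.
Compound 3, `Nc1nc(Cl)c2ncn(Cc3ccccc3CCl)c2n1`, gives 19100 nM.

Compounds 1 and 2 have the same atoms joined differently; the difference between the two cores is not broken down here. Compound 3 arises from compound 1 by amino in place of chloro on an aromatic carbon, and this gave an at least 5.2-fold lower number from compound 1 to compound 3 (0.71 log units; beyond the scatter). Since two of the three values sit at the limit of > 100000 nM in this assay, at which 2 of the 3 values shown sit, the size of that step is known only as a bound. Compound 4, `Nc1nc(Cl)c2ncn(Cc3cccc(CCl)c3)c2n1`, not yet measured, arises from compound 2 by the same change, (amino in place of chloro on an aromatic carbon). On the basis of the step of an at least 5.2-fold lower number from compound 1 to compound 3 (0.71 log units; beyond the scatter), the same change is expected to give an at least 4.0-fold lower number from compound 2 to compound 4 (0.60 log units; beyond the scatter). Compound 4 is therefore expected at 25000 nM, with a range from 8000 nM to 100000 nM.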

Compound 4, concentration for total growth inhibition: 9770 nM
Estimate against measurement, compound 4: 2.6-fold (0.41 log units) above; the range from low to high includes it.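

In this assay, amino in place of chloro on an aromatic carbon again gives a lower number on the second core, with an at least 10-fold lower number from compound 2 to compound 4 (1.01 log units; beyond the scatter). Set beside the earlier step, the comparison reads: the same change on two cores in this assay, an at least 5.2-fold lower number (0.71 log units; beyond the scatter) from compound 1 to compound 3 and an at least 10-fold lower number (1.01 log units; beyond the scatter) from compound 2 to compound 4; the limit leaves it open whether they differ. The direction of the change therefore holds on both cores shown, but this rests on only two cores, and the starting value of each step is a limit, so neither true size is known and the steps cannot be ranked: the limit of > 100000 nM in this assay, at which 2 of the 4 values shown sit.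

The compounds shown leave open whether a methylamino or hydroxyl group in the same place would also lower the number. They also leave open how far a step would carry to a core with a longer chain in place of the chloromethyl group.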